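The source may hold more compounds than are shown below. What is called first, only, known or untested is meant among the compounds shown, and "the series" means these compounds.

Of the compounds shown here, three have so far been measured in a functional assay on cells (T-cell line, Homo sapiens) for inhibition; on this read-out higher numbers stand for weaker inhibition and lower numbers for stronger inhibition. Compound 1 `COc1ccc(CCCN2CCC(COCc3ccc(Cl)c(Cl)c3)CC2)cc1` gives 200 nM in this assay. Compound 2 `COc1ccc(CCCN2CCC(=CCC(c3ccccc3)c3ccccc3)CC2)cc1` gives 400 nM in this assay; the two values lie within the usual scatter of each other. For compound 3 `CN1CCC(COC(c2ccccc2)c2ccccc2)CC1` the read-out is a limit of the assay and not a number: > 20000 nM. Compound 3 thus stands at the limit of > 20000 nM in this assay, at which 1 of the 3 values shown sits. Compound 4 `CCCCN1CCC(COC(c2ccccc2)c2ccccc2)CC1` differs from compound 3 by propyl in place of hydrogen on a saturated chain carbon bound to an amine nitrogen in a ring. Among the measured compounds shown here, since no measured pair shares this change, the expectation rests on compound 3 alone, whose value in this assay is only a limit. Compound 4 is expected to give about 10000 nM, between 2500 nM and 40000 nM. That estimate implies an expected step of an at least 2.0-fold lower number from compound 3 to compound 4 (0.30 log units; that floor lies within the scatter), still within a weakly inhibiting range.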

Compound 4, half-maximal inhibitory concentration: 14000 nM
Compound 4: middle estimate off by 1.4-fold (0.15 log units), on the low side, within the range that was stated.
By their numbers in this assay, from the lowest: compounds 1 and 2 (each within the scatter of the next); then compound 4. At a limit, above all of these: compound 3.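

Propyl in place of hydrogen on a saturated chain carbon bound to an amine nitrogen in a ring gives an at least 1.4-fold lower number from compound 3 to compound 4 (0.15 log units; that floor lies within the scatter) in this assay, so butyl at this place yields a readable number. Compound 3 remains a limit of the assay: the limit of > 20000 nM in this assay, at which 1 of the 4 values shown sits. From the compounds shown here alone, the true size of the step therefore stays unknown, and its printed floor alone shows no change beyond the scatter.

The compounds shown leave open how a hexyl chain or a benzyl group would read at this place. They also leave open what a carboxylic acid at the end of the butyl chain would do.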